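A few compounds are considered here, and "the series" means these few. Any claim that something is new, unique, unknown or untested is made for them only; others in the source may bear on it.

Compound 1 `COc1ccccc1-c1cccc(CN(C)C)c1` carries a (dimethylamino)methyl group on the shared core; in an assay on HEK293 cells for displacement of a labelled ligand from 5-hydroxytryptamine receptor 7 (Homo sapiens), read by scintillation counting, with a stated time of 1.5 h, in the absence of a further agent (a higher number here means a weaker inhibitor, a lower number a stronger inhibitor), compound 1 gives 126 nM. Compound 2 `CNCc1cccc(-c2ccccc2OC)c1` differs from it by hydrogen in place of methyl on an amine nitrogen and in this assay compound 2 gives 226 nM, a step of a 1.8-fold higher number from compound 1 to compound 2 (0.25 log units; within the scatter). Compound 3 `COc1ccccc1-c1cc(CN(C)C)ccc1OC` differs from compound 1 in the core by methoxy in place of hydrogen on an aromatic carbon, a step of an 8.1-fold higher number from compound 1 to compound 3 (0.91 log units; beyond the scatter); in this assay compound 3 gives 1020 nM. Compound 4 `CNCc1ccc(OC)c(-c2ccccc2OC)c1` is not yet measured and differs from compound 3 by hydrogen in place of methyl on an amine nitrogen, the same change as from compound 1 to compound 2, at a place described in the same words. On the core of compound 3 the step is expected to be a 1.8-fold higher number from compound 3 to compound 4 (0.25 log units; within the scatter), set beside a 1.8-fold higher number from compound 1 to compound 2 (0.25 log units; within the scatter), and it rests on that single pair because a 1.8-fold higher number from compound 1 to compound 2 (0.25 log units; within the scatter) lay within the scatter. Compound 4 is thus expected to give 1800 nM in this assay, between 900 nM and 3600 nM.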

Compound 4, inhibition constant: 648 nM
Compound 4: middle estimate off by 2.8-fold (0.44 log units), on the high side; the whole stated range lies above it.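

In this assay, hydrogen in place of methyl on an amine nitrogen gives a 1.6-fold lower number from compound 3 to compound 4 (0.20 log units; within the scatter) and does not carry over from the core of compound 1 as one fixed step: the same change on two cores in this assay, a 1.8-fold higher number (0.25 log units; within the scatter) from compound 1 to compound 2 and a 1.6-fold lower number (0.20 log units; within the scatter) from compound 3 to compound 4, 2.8-fold (0.45 log units) apart, beyond the scatter of two such steps. Methoxy in place of hydrogen on an aromatic carbon gives a higher number on both amines, seen here as a 2.9-fold higher number from compound 2 to compound 4 (0.46 log units; beyond the scatter) but with a size that depends on the amine: the same change on two cores in this assay, an 8.1-fold higher number (0.91 log units; beyond the scatter) from compound 1 to compound 3 and a 2.9-fold higher number (0.46 log units; beyond the scatter) from compound 2 to compound 4, 2.8-fold (0.45 log units) apart, beyond the scatter of two such steps. Both gaps rest on the same compounds and form one observation that the two changes do not simply add, and they show neither a cause nor whether this holds on another core.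

Open, as far as these compounds go, is whether the primary amine or a longer chain on the amine nitrogen would follow the same course. Also open, from the compounds shown here alone, is how fluorine or hydroxyl in place of the added methoxy would behave.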